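Bromo to chloro on the 2-bromophenyl group

This account rests on a few compounds, and the source may have more. Where it says the series, first, only, none or still open, it means among the compounds named here.

Measured so far in a functional assay on A549 cells (Homo sapiens) for antiproliferative activity, read by MTT assay, with a stated time of 72 h; a lower number here means a stronger inhibitor, a higher number a weaker inhibitor
compound 1 `NC1=NC2(CCSCC2)N(OCCCOc2ccc(Br)cc2)C(N)=N1` gives 740 nM
compound 2 `NC1=NC2(CCSCC2)N(OCCCOc2ccccc2Br)C(N)=N1` gives 40 nM

Compound 2 holds the lower of the two numbers. Within the data shown here, the only measured step is a 19-fold lower number from compound 1 to compound 2 (1.27 log units; beyond the scatter) and it is large, beyond the scatter, but it moves the bromine rather than replacing it. Compound 3 `NC1=NC2(CCSCC2)N(OCCCOc2ccccc2Cl)C(N)=N1` differs by chloro in place of bromo on an aromatic carbon with chloro in place of bromo on an aromatic carbon, ortho to a large group. Among the measured compounds shown here, no measured step exchanges one halogen for another, so that step bears only loosely here. The expected step in this assay is a 1.4-fold higher number from compound 2 to compound 3 (0.14 log units; within the scatter) and is estimated to stay within the scatter. The expected value for compound 3 is 55 nM with an estimated range from 20 nM to 150 nM.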

Compound 3, half-maximal inhibitory concentration: 80 nM
Estimate against measurement, compound 3: 1.5-fold (0.16 log units) below, and the stated range covers the measured number.
By their numbers in this assay, from the lowest: compounds 2 and 3 (each within the scatter of the next); then compound 1.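

In this assay, chloro in place of bromo on this aromatic carbon gives a 2.0-fold higher number from compound 2 to compound 3 (0.30 log units; within the scatter), so among the compounds shown, this exchange does not separate the two halogens. The 2-chlorophenyl compound also keeps a clear distance from the 4-bromophenyl compound, with a 9.3-fold lower number from compound 1 to compound 3 (0.97 log units; beyond the scatter), so the low numbers of the 2-halophenyl compounds are not confined to bromo. No supporting measurement accounts for either step.

The compounds shown leave open how a fluoro, methyl or methoxy group on the same carbon would read. They also leave open whether a longer chain to the phenoxy group would keep these numbers.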